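Chloromethylbenzyl chloropurines: second chloro on the core

This account rests on a few compounds, and the source may have more. Where it says the series, first, only, none or still open, it means among the compounds named here.

Measured so far:
compound 1, `ClCc1ccc(Cn2cnc3c(Cl)ncnc32)cc1` — 1380 nM
compound 2, `ClCc1ccccc1Cn1cnc2c(Cl)ncnc21` — 7760 nM

In a functional assay on A549 cells (Homo sapiens) for cytotoxicity, read by sulforhodamine B assay, with a stated time of 48 h (on this read-out higher numbers stand for weaker inhibition of growth and lower numbers for stronger inhibition of growth), compound 1 gives 1380 nM, the lower of the two numbers in hand. Compound 2 gives 7760 nM, a higher number, and the gap between compound 1 and compound 2 lies beyond the scatter. For the measured compounds named here, these two compounds differ only in where the chloromethyl group sits on the benzyl ring, and no pair among them shows a change on the core itself.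

Compound 3, `ClCc1ccc(Cn2cnc3c(Cl)nc(Cl)nc32)cc1`, is not yet measured. It differs from compound 1 by chloro in place of hydrogen on an aromatic carbon. Going by the values given here, no measured pair shows a change of this kind, so the size of the step in this assay cannot be read from the two compounds in hand. With the benzyl part and its chloromethyl group kept unchanged, the working expectation is a step of modest size at most, direction uncertain, and quite possibly none beyond the scatter.

Compound 3 is therefore expected to give about 1100 nM in this assay, with a range from 350 nM to 3500 nM. Compound 3 is thus expected to show a step of a 1.3-fold lower number from compound 1 to compound 3 (0.10 log units; within the scatter).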

Compound 3, concentration for 50% growth inhibition: 18600 nM
Estimate against measurement, compound 3: 17-fold (1.23 log units) below; the measured number lies above the stated range.
By their numbers in this assay, from the lowest: compound 1; then compound 2; then compound 3.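

In this assay chloro in place of hydrogen on the aromatic carbon between two ring nitrogen atoms is far from a neutral change, and the step is large (a 13-fold higher number from compound 1 to compound 3 (1.13 log units; beyond the scatter)). For the compounds shown here, this is the first change on the core: the earlier pair spoke only to where the chloromethyl group sits on the benzyl ring, whereas this pair shows that one added heavy atom on the core, with the benzyl part and its chloromethyl group unchanged, can weaken growth inhibition beyond the scatter. Going by these compounds alone, nothing measured so far accounts for this loss.

As far as these compounds go, the pair tests only chloro at this position, so it remains open whether the loss is particular to chloro or extends to other groups there, such as an amine, a methyl or a methoxy group, any of which could show how far the position accepts substitution at all. From the compounds shown here alone, it also remains open whether the same change carries a step of similar size when the chloromethyl group sits on the benzyl ring as in compound 2.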